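The source may report more compounds than this note shows. Statements on the series, on what has been measured and on what is new or still open speak of the compounds shown alone.

Values measured in a physicochemical assay for lipophilicity, at pH 7.4; a higher number here means a more lipophilic compound, a lower number a more polar compound:

- compound 1 `CNC(=O)c1cc(C(=O)N[C@H]2CC[C@H](O)CC2)cc2c1OC[C@@]2(C)c1ccccc1` gives 3.3
- compound 2 `CNC(=O)c1cc(C(=O)N[C@H]2C[C@@H]2C)cc2c1OC[C@@]2(C)c1ccccc1` gives 4.7
- compound 3 `CNC(=O)c1cc(C(=O)NC2CC2)cc2c1OC[C@@]2(C)c1ccccc1` gives 4

Compound 3 , at 4, holds the middle place among these three numbers. Compound 1 lies below it and compound 2 above it.

The next compound to consider is compound 4 `CNC(=O)c1cc(C(=O)N[C@H]2[C@@H]3C[C@@H](O)C[C@@H]32)cc2c1OC[C@@]2(C)c1ccccc1`, which keeps the shared core and differs from compound 3 only in the group on an amide-type nitrogen: a group of 7 heavy atoms (6 carbon, 1 oxygen; one three-membered non-aromatic ring of carbon only, one five-membered non-aromatic ring of carbon only) in place of a group of 3 heavy atoms (3 carbon; one three-membered non-aromatic ring of carbon only), on an amide-type nitrogen. Cyclopropyl leaves, and the group that enters contains oxygen.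

The closest measured comparison is a number 0.70 log units higher from compound 1 to compound 3 (beyond the scatter), where cyclopropyl stands in place of 4-hydroxycyclohexyl on an amide-type nitrogen. That change also swaps cyclopropyl and an oxygen-bearing group, but in the opposite direction, so a fall of similar size is expected here. Two other steps, a number 1.40 log units higher from compound 1 to compound 2 (beyond the scatter) and a number 0.70 log units lower from compound 2 to compound 3 (beyond the scatter), both involve a methyl on a saturated ring carbon and therefore bear on this change less directly.

The step expected in this assay is a number 0.70 log units lower from compound 3 to compound 4 (beyond the scatter). For the measured compounds named here, no compound measured so far carries the entering group itself, so the range is kept fairly wide. For compound 4 the estimated value is 3.3, with an expected range from 2.9 to 3.7.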

Compound 4, distribution coefficient: 3.3
The estimate for compound 4 equals the measured number at the digits printed; measured number inside the range.
By their numbers in this assay, from the lowest: compounds 1 and 4 (each within the scatter of the next); then compound 3; then compound 2.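

In this assay the new group on the amide-type nitrogen has 7 heavy atoms (6 carbon, 1 oxygen) arranged as a three-membered ring and a five-membered ring, while 4-hydroxycyclohexyl has the same count in one six-membered ring; the result is no change at the digits printed from compound 1 to compound 4 (within the scatter) and shows that, for this pair, changing the ring framework leaves the number unmoved. Against the groups without oxygen, the result is a number 0.70 log units lower from compound 3 to compound 4 (beyond the scatter) for cyclopropyl and a number 1.40 log units lower from compound 2 to compound 4 (beyond the scatter) for 2-methylcyclopropyl, so across these four compounds both oxygen-bearing groups give lower numbers than both carbon-only groups, and no compound goes against this. Nothing at hand explains why these numbers fall as they do.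

The compounds shown leave open what plain cyclohexyl would give on this nitrogen, which would separate the contribution of the oxygen from that of the larger ring. They also leave open whether an amine or a carboxylic acid on the same two-ring group would give a number close to that of the hydroxyl-bearing compounds, and how the other stereoisomers of the group would compare.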